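The source may hold more compounds than are shown below. What is called first, only, known or untested is meant among the compounds shown, and "the series" means these compounds.

The measured compounds:
compound 1, `O=C1C(O)=C(C(c2cccc([N+](=O)[O-])c2)c2c[nH]c3ccccc23)C(=O)c2ccccc21`, in a toxicity assay (Homo sapiens) for cytotoxicity, read by MTT assay, with a stated time of 48 h (on this read-out lower numbers stand for stronger inhibition and higher numbers for weaker inhibition), compound 1 gives 91200 nM
compound 2, `O=C1C(O)=C(C(c2ccc([N+](=O)[O-])cc2)c2c(-c3ccccc3)[nH]c3ccccc23)C(=O)c2ccccc21`, in this assay compound 2 gives 14200 nM
compound 3, `O=C1C(O)=C(C(c2ccccc2)c2c(-c3ccccc3)[nH]c3ccccc23)C(=O)c2ccccc21`, in this assay compound 3 gives 26400 nM

Compound 3 stands second highest of the three numbers; its nearest neighbour is compound 2, and compound 1 is the furthest away. The unmeasured compound 4, `O=C1C(O)=C(C(c2cccc([N+](=O)[O-])c2)c2c(-c3ccccc3)[nH]c3ccccc23)C(=O)c2ccccc21`, differs from compound 3 by one change: nitro in place of hydrogen on an aromatic carbon.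

Among the compounds with values here, one measured step bears on this change, in the opposite direction: a 1.9-fold higher number from compound 2 to compound 3 (0.27 log units; within the scatter). Reversing it, a nitro group entering a phenyl ring on this shared core gave only a small shift, within the scatter, though there the nitro sat at a different place. Within the data shown here, compound 1 also carries a 3-nitrophenyl group, but it lacks the phenyl on the indole of compound 4, and no single step links it to compound 3 or compound 4. The account therefore expects, for compound 4 in this assay, a step of a 1.5-fold lower number from compound 3 to compound 4 (0.17 log units; within the scatter), towards a somewhat lower number but not clearly beyond the scatter. Compound 4 is estimated at 18000 nM, with a range from 8000 nM to 45000 nM.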

Compound 4, half-maximal inhibitory concentration: 13400 nM
Compound 4: the middle estimate sits 1.3-fold (0.13 log units) above what was measured, within the range that was stated.
By their numbers in this assay, from the lowest: compounds 4, 2 and 3 (each within the scatter of the next); then compound 1.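

In this assay, the change from phenyl to 3-nitrophenyl on the shared core gives a 2.0-fold lower number from compound 3 to compound 4 (0.29 log units; within the scatter) and so, at this place too, a nitro group brings no shift beyond the scatter. Moving from 4-nitrophenyl to 3-nitrophenyl gives a 1.1-fold lower number from compound 2 to compound 4 (0.03 log units; within the scatter) and so the two nitro placements cannot be told apart on this read-out. Within the data shown here, the new compound also supplies the first single step beyond the scatter, since with the 3-nitrophenyl group held fixed, adding a further phenyl group gives a 6.8-fold lower number from compound 1 to compound 4 (0.83 log units; beyond the scatter) and so the larger change lies at that other place rather than at the nitro group.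

On these data alone, whether an amine or a carboxylic acid on this ring would move the number beyond the scatter stays open. Nothing shown here gives a reason for any of these steps.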